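Methoxy to fluoro on the amine-bearing ring: working notes

The source may report more compounds than this note shows. Statements on the series, on what has been measured and on what is new or still open speak of the compounds shown alone.

Measured so far:
compound 1 `COc1cccc(Nc2nccc(-c3ccncc3)n2)c1`, 400 nM
compound 2 `COc1cccc(Nc2nccc(-c3ccsc3)n2)c1`, 1800 nM

Within the data shown here, in a functional assay for inhibition, with Homo sapiens as the target (a lower number here means a stronger inhibitor, a higher number a weaker inhibitor), compound 1 gives 400 nM, the lowest of the two numbers; the only other number lies a 4.5-fold higher number from compound 1 to compound 2 (0.65 log units; beyond the scatter). Compound 3 `Fc1cccc(Nc2nccc(-c3ccncc3)n2)c1` differs from compound 1 by fluoro in place of methoxy on an aromatic carbon, on an aromatic carbon meta to a large group. Among the measured compounds shown here, the single measured step, a 4.5-fold higher number from compound 1 to compound 2 (0.65 log units; beyond the scatter), concerns the other ring and does not bear on this exchange, so no measured step informs it. A step in this assay of at most modest size is therefore expected, likely within the scatter or a slight weakening, a 1.6-fold higher number from compound 1 to compound 3 (0.21 log units; within the scatter). Compound 3 is estimated at 650 nM, between 200 nM and 2200 nM.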

Compound 3, half-maximal inhibitory concentration: 700 nM
The estimate for compound 3 lay 1.1-fold (0.03 log units) below the measured number, within the range that was stated.
By their numbers in this assay, from the lowest: compounds 1 and 3 (each within the scatter of the next); then compound 2.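

In this assay, among these compounds, fluoro in place of methoxy on an aromatic carbon meta to a large group gives a 1.8-fold higher number from compound 1 to compound 3 (0.24 log units; within the scatter) and thus the first reading at this position: the exchange leaves the number within the scatter. Among the compounds shown here, the only earlier step, a 4.5-fold higher number from compound 1 to compound 2 (0.65 log units; beyond the scatter) and so beyond the scatter, concerned the other ring. No available evidence explains why methoxy and fluoro read alike here.

Still open, from the compounds shown here alone, is how an amine, a carboxylic acid or a longer chain would read at this position. Also open, going by these compounds, is whether fluoro reads the same with thiophen-3-yl on the other ring.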